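Aryl amine variation on the shared core: compound 4

The source may report more compounds than this note shows. Statements on the series, on what has been measured and on what is new or still open speak of the compounds shown alone.

Measured so far:
- compound 1, `Cc1ccc(NC2=CC(=O)c3nc4n(c3C2=O)[C@H]2OC[C@@H](O)[C@H]2OC4)cc1C`, in a functional assay on MCF7 cells (Homo sapiens) for inhibition, read by sulforhodamine B assay (a higher number here means a weaker inhibitor, a lower number a stronger inhibitor), 2080 nM
- compound 2, `O=C1C(NC2CCCCC2)=CC(=O)c2c1nc1n2[C@H]2OC[C@@H](O)[C@H]2OC1`, this assay > 16000 nM (a limit of the assay, not a number)
- compound 3, `CCc1ccc(NC2=CC(=O)c3c(nc4n3[C@H]3OC[C@@H](O)[C@H]3OC4)C2=O)cc1`, this assay 8990 nM

Compound 1 gives the lowest number of the two numbers shown; the nearest is compound 3, whose number is higher, a gap beyond the scatter. Compound 2 reports only a limit, (the limit of > 16000 nM in this assay, at which 1 of the 3 values shown sits).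

Compound 4, `O=C1C=C(Nc2ccccc2F)C(=O)c2c1nc1n2[C@H]2OC[C@@H](O)[C@H]2OC1`, carries the change (2-fluorophenyl in place of 3,4-dimethylphenyl on an amine nitrogen). Among the compounds with values here, the one measured step, an at least 1.7-fold lower number from compound 2 to compound 3 (0.25 log units; that floor lies within the scatter), concerns cyclohexyl against 4-ethylphenyl on the same amine nitrogen and does not bear directly on the swap of one aryl group for another; its size is anyway at the floor of a limit. What the two aryl amines, compound 1 and compound 3, show is that the number shifts clearly with the substitution pattern on the ring. For compound 4 a step of a 2.9-fold higher number from compound 1 to compound 4 (0.46 log units; beyond the scatter) toward a higher number is therefore expected, its size uncertain. The estimate for compound 4 in this assay is 6000 nM, within 2000 nM to 18000 nM.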

Compound 4, half-maximal inhibitory concentration: 3640 nM
Compound 4: middle estimate off by 1.6-fold (0.22 log units), on the high side, within the range that was stated.
By their numbers in this assay, from the lowest: compounds 1 and 4 (each within the scatter of the next); then compound 3. At a limit, above all of these: compound 2.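

The swap of 3,4-dimethylphenyl for 2-fluorophenyl on the amine nitrogen gives a 1.8-fold higher number from compound 1 to compound 4 (0.24 log units; within the scatter) in this assay, so the two aryl groups cannot be told apart at this position. The earlier compounds shown here held no readable step between two aryl groups on this nitrogen; this one shows that a ring with a single fluorine and a ring with two methyl groups can give values within the scatter of each other. Nothing at hand gives a reason for this result.

From the compounds shown here alone, the swap removes both methyl groups and adds the fluorine in one step, so the contribution of each stays open. Also open, going by these compounds, is how a 4-fluorophenyl group, a pyridine ring or a carboxylic acid on the aryl ring would read in this assay.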